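The source may hold more compounds than are shown below. What is called first, only, known or untested is meant among the compounds shown, and "the series" means these compounds.

Measured compounds:

Compound 1, `O=C1C(=O)N(CN(c2ccccc2)c2ccccc2)c2cccc(Cl)c21`: 14400 nM
Compound 3, `O=C1C(=O)N(CN(c2ccccc2)c2ccccc2)c2cccc(Br)c21`: 63300 nM
Compound 2, `Cc1ccc2nc(/N=C3\C(=O)N(CN(c4ccccc4)c4ccccc4)c4cccc(Br)c43)sc2c1`: 82300 nM

Three compounds were examined in a functional assay on MDA-MB-468 cells (Homo sapiens) for cytotoxicity, read by sulforhodamine B assay, with a stated time of 48 h (on this read-out lower numbers stand for stronger inhibition of growth and higher numbers for weaker inhibition of growth), all built on a shared framework. Compound 1 and compound 3 differ in one place only, (chloro in place of bromo on an aromatic carbon). That single change gave a 4.4-fold lower number from compound 3 to compound 1 (0.64 log units; beyond the scatter), so the compound bearing chloro gives the lower number of the pair. Compound 2 carries a different core from compound 3; how the two cores differ is not broken down here. In this assay compound 2 gives a number that lies within the scatter of the number for compound 3, so no order between those two can be read, while against compound 1 its number is clearly higher.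

Compound 4, `Cc1ccc2nc(/N=C3\C(=O)N(CN(c4ccccc4)c4ccccc4)c4cccc(Cl)c43)sc2c1`, has not yet been measured. It stands to compound 2 exactly as compound 1 stands to compound 3: chloro in place of bromo on an aromatic carbon. The place of the change is described in the same words in both pairs, so this is the same change, seen here for a second time. The expected step is a 3.3-fold lower number from compound 2 to compound 4 (0.52 log units; beyond the scatter), set beside the measured 4.4-fold lower number from compound 3 to compound 1 (0.64 log units; beyond the scatter), because a 4.4-fold lower number from compound 3 to compound 1 (0.64 log units; beyond the scatter) rests on a single pair and the core of compound 2 is another one, so a somewhat smaller shift is taken as the central guess, with a wide range. Compound 4 is therefore expected to give about 25000 nM in this assay, estimated to fall between 8000 nM and 75000 nM.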

Compound 4, concentration for 50% growth inhibition: 85000 nM
Compound 4: the middle estimate sits 3.4-fold (0.53 log units) below what was measured; measured number outside the range, above it.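

In this assay, putting chloro in place of bromo on the core of compound 2 gave a 1.0-fold higher number from compound 2 to compound 4 (0.01 log units; within the scatter), so no order can be read between these two compounds, whereas the same change on the core of compound 3 had given a clear shift. The change therefore did not carry over unchanged from one core to the other: the same change on two cores in this assay, a 4.4-fold lower number (0.64 log units; beyond the scatter) from compound 3 to compound 1 and a 1.0-fold higher number (0.01 log units; within the scatter) from compound 2 to compound 4, 4.5-fold (0.66 log units) apart, beyond the scatter of two such steps. This shows that the shift seen on one core cannot be assumed for the other, but it does not show what about the two cores sets them apart, and with a single pair on each core it gives no rule for any further core.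

The compounds shown leave open how a fluoro, a methoxy or a nitrile on the same aromatic carbon would read on either core, and so whether the two cores part in the same way for groups other than chloro and bromo. Going by these compounds, it also remains open whether an amine or a carboxylic acid in place of the methyl of compound 4 would alter the picture on that core.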